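The compounds below may be only part of what the source reports. "The series", "measured", "known", "first", "only" and "open" are said of these compounds alone.

In an ADME assay on THP-1 cells (Homo sapiens) for cytotoxicity, read by resazurin assay, with a stated time of 48 h (a lower number here means a stronger inhibitor, a higher number a weaker inhibitor), compound 1 `O=c1c(O)cccn1Cc1ccc(-c2ccccc2)cc1` reads > 10 ug/mL, which is a limit. Compound 2 `N#Cc1ccc(-c2ccc(Cn3cccc(O)c3=O)cc2)cc1` reads > 10 ug/mL, also a limit and not a number. Compound 3 `N#Cc1ccccc1-c1ccc(Cn2cccc(O)c2=O)cc1` reads > 10 ug/mL, again a limit. Among the measured compounds shown here, compound 2 therefore has no numerical position, and the series so far stands at the limit of > 10 ug/mL in this assay, at which 3 of the 3 values shown sit.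

Next in the series is compound 4 `CN(C)c1ccc(-c2ccc(Cn3cccc(O)c3=O)cc2)cc1`, not yet measured, with dimethylamino in place of cyano on an aromatic carbon, para to a large group: dimethylamino in place of cyano on an aromatic carbon.

The nearest measured changes concern the cyano group, and they are a step that the two limits leave unreadable from compound 1 to compound 2 and a step that the two limits leave unreadable from compound 1 to compound 3. Neither gives a size or a direction, so no step beyond the scatter is expected in this assay. The estimated change is a step that the limit leaves unreadable from compound 2 to compound 4. Compound 4 is expected at 15 ug/mL, with an estimated range from 6 ug/mL to 40 ug/mL.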

Compound 4, half-maximal inhibitory concentration: > 10 ug/mL
Compound 4: only a limit was reported (the forecaster's own chance of this, stated with the estimate: 75%); the middle value lies beyond the limit too.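

In this assay no new step can be read for compound 4 against compound 1 or compound 2, as all the values are limits and not numbers: the limit of > 10 ug/mL in this assay, at which 4 of the 4 values shown sit. The compounds shown leave open where any of them would fall numerically, and whether cyano or dimethylamino changes the read-out at all.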